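Furan in place of pyridine on a hydrazone carbon

This account rests on a few compounds, and the source may have more. Where it says the series, first, only, none or still open, it means among the compounds named here.

Measured so far in an assay on isolated protein for inhibition of Amine oxidase [flavin-containing] A (Homo sapiens), read by fluorescence; on this read-out higher numbers stand for weaker inhibition and lower numbers for stronger inhibition:
compound 1, `COc1cccc(-c2csc(N/N=C/c3ccco3)n2)c1`, gives 343 nM;
compound 2, `COc1cccc(-c2csc(N/N=C/c3ccncc3)n2)c1`, gives 698 nM;
compound 3, `COc1cccc(-c2csc(N/N=C(\C)c3ccncc3)n2)c1`, gives 3710 nM.

Compound 3 stands highest of the three; the nearest to it is compound 2 and the furthest is compound 1. The difference between the cores of compound 2 and compound 3 is not broken down here.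

Between compound 2 and compound 1 one change is made: furan-2-yl in place of pyridin-4-yl on a carbon with a double bond to nitrogen. This gave a 2.0-fold lower number from compound 2 to compound 1 (0.31 log units; beyond the scatter) in this assay.

Compound 4, `COc1cccc(-c2csc(N/N=C(\C)c3ccco3)n2)c1`, has not yet been measured. It differs from compound 3 by furan-2-yl in place of pyridin-4-yl on a carbon with a double bond to nitrogen. Going by the values given here, this is the same kind of change as the one from compound 2 to compound 1, not the same: around the place, the carbon with the double bond to nitrogen carries a saturated chain carbon as a further neighbour in compound 3 and compound 4, and not in compound 2 and compound 1. Resting on compound 2 and compound 1, where the step was a 2.0-fold lower number from compound 2 to compound 1 (0.31 log units; beyond the scatter), a step of similar size is expected for compound 4, estimated as a 2.0-fold lower number from compound 3 to compound 4 (0.30 log units; within the scatter). Compound 4 is therefore expected to give about 1850 nM in this assay, estimated between 800 nM and 4500 nM.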

Compound 4, half-maximal inhibitory concentration: 333 nM
Compound 4: the middle estimate sits 5.6-fold (0.74 log units) above what was measured, and the stated range ends above it.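

In this assay, furan-2-yl in place of pyridin-4-yl on a carbon with a double bond to nitrogen, whose other neighbours are the double-bonded nitrogen and a saturated chain carbon, gave an 11-fold lower number from compound 3 to compound 4 (1.05 log units; beyond the scatter). The change lowered the number on both cores, but its size did not carry from one core to the other: the same change on two cores in this assay, a 2.0-fold lower number (0.31 log units; beyond the scatter) from compound 2 to compound 1 and an 11-fold lower number (1.05 log units; beyond the scatter) from compound 3 to compound 4, 5.5-fold (0.74 log units) apart, beyond the scatter of two such steps. This shows that the direction held in these two pairs and that the size of the step on one core was a poor guide to its size on the other, but two pairs show neither a general rule for the series nor why the steps differ.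

The compounds shown leave open whether a thiophene-2-yl or a phenyl group in place of furan-2-yl would show a similar gap between the two cores. They also leave open how large the step would be with a longer chain on that same carbon.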